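This account rests on a few compounds, and the source may have more. Where it says the series, first, only, none or still open, it means among the compounds named here.

Two compounds of the series carry a measurement. Compound 1 `Cc1nc2c3ccccc3ccc2c2nc3c(ccc4ccccc43)c(-c3cccc([N+](=O)[O-])c3)c12` gives in a functional assay, with a stated time of 90 s (on this read-out higher numbers stand for weaker inhibition and lower numbers for stronger inhibition), a value of 157 ug/mL. Compound 2 `Cc1nc2c3ccccc3ccc2c2nc3c(ccc4ccccc43)c(-c3cccc4ccccc34)c12` gives in this assay a value of 179 ug/mL. Within the data shown here, compound 2 thus holds the higher of the two numbers, with compound 1 as its only neighbour; the step of a 1.1-fold higher number from compound 1 to compound 2 (0.06 log units; within the scatter) is the sole measured change, an exchange of 3-nitrophenyl for naphthalen-1-yl on an aromatic carbon of the shared core, and it stays inside the scatter.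

Compound 3 `Cc1nc2c3ccccc3ccc2c2nc3c(ccc4ccccc43)c(-c3cc([N+](=O)[O-])ccc3N)c12` follows from compound 2 by 2-amino-5-nitrophenyl in place of naphthalen-1-yl on an aromatic carbon. The entering group brings a nitro substituent back onto the aryl ring, as in compound 1, together with an amino group. Among the measured compounds shown here, the one step available for comparison, a 1.1-fold higher number from compound 1 to compound 2 (0.06 log units; within the scatter), shows that swapping 3-nitrophenyl for naphthalen-1-yl at this carbon left the read-out unmoved; a return toward a nitrophenyl is therefore not expected to shift it either. The expected step is a 1.1-fold lower number from compound 2 to compound 3 (0.05 log units; within the scatter), within the scatter. Compound 3 is expected to give 160 ug/mL, with a range from 80 ug/mL to 320 ug/mL.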

Compound 3, half-maximal inhibitory concentration: 110 ug/mL
Compound 3: middle estimate off by 1.5-fold (0.16 log units), on the high side; low and high end bracket the measured number.
By their numbers in this assay, from the lowest: compounds 3, 1 and 2 (each within the scatter of the next).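

In this assay, among these compounds, the step of a 1.4-fold lower number from compound 1 to compound 3 (0.15 log units; within the scatter) gives the first reading of a substituent added to the aryl ring with the nitro group kept, amino in place of hydrogen on an aromatic carbon, and this addition does not carry the number outside the scatter. The step of a 1.6-fold lower number from compound 2 to compound 3 (0.21 log units; within the scatter) extends this to a larger change, since the two carbon rings of naphthalen-1-yl give way to the single ring of 2-amino-5-nitrophenyl, which brings a hydrogen-bond donor and hydrogen-bond acceptors where naphthalen-1-yl has none, and this too stays within the scatter. This aromatic carbon, opposite the ring nitrogen, thus carries all three aryl groups with no step beyond the scatter, and no accompanying measurement bears on these numbers.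

Still open, on these data alone, is whether a group of another kind at this carbon, such as a carboxylic acid, a morpholine or a plain alkyl chain, would give a step beyond the scatter. Also open, as far as these compounds go, is what a phenyl ring carrying amino without nitro would give, and whether any other group in place of the methyl on the shared core would move the number.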